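Amide replacement of the side-chain acid in the dichlorophenyl series

A few compounds are considered here, and "the series" means these few. Any claim that something is new, unique, unknown or untested is made for them only; others in the source may bear on it.

Measured compounds:
compound 1 `CC(=O)NCC[C@@H]1C[C@@H](c2ccc(F)c(F)c2)[C@H](NC(=O)c2cc(-c3c(Cl)cnn3C)c(Cl)o2)CN1` 880 nM
compound 2 `Cn1ncc(Cl)c1-c1cc(C(=O)N[C@@H]2CN[C@H](CC(=O)O)C[C@H]2c2ccc(Cl)c(Cl)c2)oc1Cl` 5120 nM
compound 3 `Cn1ncc(Cl)c1-c1cc(C(=O)N[C@@H]2CN[C@H](CCN3CCC(O)CC3)C[C@H]2c2ccc(Cl)c(Cl)c2)oc1Cl` 15900 nM

In a functional assay on OVCAR-8 cells (Homo sapiens) for antiproliferative activity (on this read-out lower numbers stand for stronger inhibition and higher numbers for weaker inhibition), compound 2 gives 5120 nM, the second highest of the three numbers; it sits nearer to compound 3 than to compound 1. Compound 4 `CNC(=O)C[C@@H]1C[C@@H](c2ccc(Cl)c(Cl)c2)[C@H](NC(=O)c2cc(-c3c(Cl)cnn3C)c(Cl)o2)CN1` is the methylamide of compound 2: methylamino in place of hydroxy on a carbonyl carbon. Among the compounds with values here, only one measured step on the same chain bears on it, the step of a 3.1-fold higher number from compound 2 to compound 3 (0.49 log units; beyond the scatter), which removed the carboxy in favour of a basic ring and weakened the read-out. Compound 1, which carries a neutral acetamide on its chain, gives 880 nM, but it also differs in the aryl halogens and in chain length, so its two values with compound 2 are shown, not a step. A neutral amide on this chain is therefore expected to give a modestly lower number in this assay, with the step of a 2.3-fold lower number from compound 2 to compound 4 (0.37 log units; beyond the scatter) as the working expectation. Compound 4 is estimated at 2200 nM, in the range 700 nM to 7000 nM.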

Compound 4, half-maximal inhibitory concentration: 1130 nM
Compound 4: middle estimate off by 1.9-fold (0.29 log units), on the high side; the measured number falls inside the stated range.
By their numbers in this assay, from the lowest: compounds 1 and 4 (each within the scatter of the next); then compound 2; then compound 3.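

Methylamino in place of hydroxy on a carbonyl carbon gives a 4.5-fold lower number from compound 2 to compound 4 (0.66 log units; beyond the scatter) in this assay, so a carboxy group is not required at this position for the read-out. The earlier compounds shown here showed only a loss on leaving the carboxy, whereas the outcome now depends on the group that enters, with methylcarbamoyl in place of (4-hydroxypiperidin-1-yl)methyl giving a 14-fold lower number from compound 3 to compound 4 (1.15 log units; beyond the scatter) on the same saturated chain carbon. No measurement available here accounts for either step.

Open, from the compounds shown here alone, is whether a primary carboxamide, a dimethylamide or a longer chain bearing the methylcarbamoyl would hold or shift the number. Compound 1 differs from compound 4 in more than one place, so the effect of the aryl halogens and chain length cannot be separated from these values.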